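Solubility in the series: from compound 3 to compound 4

The source may hold more compounds than are shown below. What is called first, only, known or untested is meant among the compounds shown, and "the series" means these compounds.

Compound 1 `CCNC(=O)Nc1nc2cc(-c3cccnc3)cc(-c3ccccn3)c2s1` is the unsubstituted parent; in a physicochemical assay for solubility, read by turbidimetry, in phosphate buffer, with a stated time of 24 h, at pH 7.4 (on this read-out higher numbers stand for higher solubility and lower numbers for lower solubility), compound 1 gives 6.25 ug/mL. Compound 2 `CCNC(=O)Nc1nc2cc(-c3ccc(C(=O)O)nc3)cc(-c3ccccn3)c2s1` carries a carboxy group, and compound 2 gives 50 ug/mL, so an 8.0-fold higher number from compound 1 to compound 2 (0.90 log units; beyond the scatter). Compound 3 `CCNC(=O)Nc1nc2cc(-c3cnc(N4CCC(C)(C(=O)O)CC4)nc3)cc(-c3ccccn3)c2s1` reaches a limit of the assay and not a number: compound 3 gives > 800 ug/mL, which is the limit of > 800 ug/mL in this assay, at which 1 of the 3 values shown sits. Compound 4 `CCNC(=O)Nc1nc2cc(-c3cnc(N4CCC(C(=O)O)(C(F)(F)F)CC4)nc3)cc(-c3ccccn3)c2s1` differs from compound 3 by trifluoromethyl in place of methyl on a saturated ring carbon. For the measured compounds named here, no measured step covers this exchange; the only measured step concerns a carboxy group and is an 8.0-fold higher number from compound 1 to compound 2 (0.90 log units; beyond the scatter). The change keeps the carboxy group, so compound 4 is expected to stay near the limit, with a number no higher from compound 3 to compound 4 (the limit leaves the size open) estimated as no step beyond the scatter. Compound 4 is therefore estimated at 800 ug/mL, within 300 ug/mL to 1600 ug/mL.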

Compound 4, solubility: > 800 ug/mL
Compound 4: only a limit was reported; the forecaster's own chance of this, stated with the estimate: 50%; the middle value sits exactly at the limit.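

Compound 3 and compound 4 both give only a limit, so no step between them can be read: the limit of > 800 ug/mL in this assay, at which 2 of the 4 values shown sit.

On these data alone, whether trifluoromethyl in place of methyl on a saturated ring carbon shifts solubility remains open.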